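Swapping Fluoro for Diethoxymethyl on the Phenyl Ring

This account rests on a few compounds, and the source may have more. Where it says the series, first, only, none or still open, it means among the compounds named here.

Compound 2 `CC1=C(/C=C/C(=O)/C=C/c2cccc(F)c2)C(C)(C)CCC1O` gives 4400 nM in a functional assay on LNCaP cells (Homo sapiens) for cytotoxicity, read by MTT assay, with a stated time of 72 h (on this read-out lower numbers stand for stronger inhibition and higher numbers for weaker inhibition), the higher of the two numbers measured, although the step of a 1.5-fold higher number from compound 1 to compound 2 (0.18 log units; within the scatter) lies within the scatter; compound 1 `CC1=C(/C=C/C(=O)/C=C/c2ccccc2F)C(C)(C)CCC1O` gives 2900 nM. Compound 3 `CCOC(OCC)c1cccc(/C=C/C(=O)/C=C/C2=C(C)C(O)CCC2(C)C)c1` differs from compound 2 by diethoxymethyl in place of fluoro on an aromatic carbon, on an aromatic carbon of a six-membered aromatic ring of carbon only, meta to a large group. Going by the values given here, the only measured step moved a fluoro rather than replacing it, so nothing bears on this change directly and no shift beyond the scatter is expected. Compound 3 is therefore estimated at 5000 nM, between 1500 nM and 16000 nM. That expected step would be a 1.1-fold higher number from compound 2 to compound 3 (0.06 log units; within the scatter).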

Compound 3, half-maximal inhibitory concentration: 1800 nM
For compound 3 the middle estimate is 2.8-fold (0.44 log units) above the measured one; the measured number falls inside the stated range.
By their numbers in this assay, from the lowest: compounds 3, 1 and 2 (each within the scatter of the next, the first and the last beyond it).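

In this assay, the aromatic carbon that carries fluoro in compound 2 also tolerates diethoxymethyl, a group of 7 heavy atoms in place of 1, and the change gives a 2.4-fold lower number from compound 2 to compound 3 (0.39 log units; beyond the scatter) and a modest gain. Going by these compounds alone, the earlier step only moved a fluoro and stayed within the scatter, so this is the first change at this kind of place to go beyond it. No measurement shown explains the shift. Going by these compounds, whether a single methoxy, an aldehyde or an amine on this aromatic carbon would move the number in the same way remains open.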